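Ring size of the basic amine on the triazole

This account rests on a few compounds, and the source may have more. Where it says the series, first, only, none or still open, it means among the compounds named here.

Measured so far:
Compound 1 `CN(C)Cc1cn(-c2ccccc2C(=O)NCCCCCCCn2cc(-c3cccnc3)nn2)nn1` gives 42.4 nM in an assay for inhibition of Nicotinamide phosphoribosyltransferase (Mus musculus), read by fluorescence, with a stated time of 1 h, in the presence of a further agent that is not named here; on this read-out lower numbers stand for stronger inhibition and higher numbers for weaker inhibition.
Compound 2 `O=C(NCCCCCCCn1cc(-c2cccnc2)nn1)c1ccccc1-n1cc(CN2CCCCC2)nn1` gives 17.1 nM in this assay.

Compound 2 holds the lower of the two numbers. Among the measured compounds shown here, the only measured step, a 2.5-fold lower number from compound 1 to compound 2 (0.39 log units; beyond the scatter), replaced dimethylamino with piperidin-1-yl. Compound 3 `O=C(NCCCCCCCn1cc(-c2cccnc2)nn1)c1ccccc1-n1cc(CN2CCCC2)nn1` carries pyrrolidin-1-yl in place of piperidin-1-yl on a saturated chain carbon bound to an aromatic carbon, a smaller change than the one already measured, with the ring losing one carbon while the single acceptor is kept. No change beyond the scatter is expected, with a slight rise in the number as the more likely direction. Compound 3 is therefore expected near 22 nM, between 10 nM and 50 nM. This amounts to an expected 1.3-fold higher number from compound 2 to compound 3 (0.11 log units; within the scatter).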

Compound 3, half-maximal inhibitory concentration: 25.4 nM
Estimate against measurement, compound 3: 1.2-fold (0.06 log units) below; low and high end bracket the measured number.
By their numbers in this assay, from the lowest: compounds 2, 3 and 1 (each within the scatter of the next, the first and the last beyond it).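

In this assay, pyrrolidin-1-yl on this saturated chain carbon cannot be told apart from either of the other two amines: a 1.5-fold higher number from compound 2 to compound 3 (0.17 log units; within the scatter) and a 1.7-fold lower number from compound 1 to compound 3 (0.22 log units; within the scatter). Only dimethylamino and piperidin-1-yl stand apart beyond the scatter, so the ring with one carbon fewer resolves no finer trend in ring size among these compounds. Nothing at hand explains these numbers.

Still open, as far as these compounds go, is whether azepan-1-yl, with a larger ring, or morpholin-4-yl, with a ring oxygen, stays in the same range at this place.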